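A Repeated Methoxyphenyl Exchange in a Growth Inhibition Series

The source may report more compounds than this note shows. Statements on the series, on what has been measured and on what is new or still open speak of the compounds shown alone.

Compound 1 `COc1ccccc1/C=C/C(=O)/C=C/c1ccc(OCc2cn(CCCCOc3cc(=O)oc4ccccc34)nn2)c(OC)c1` and compound 2 `COc1ccc(/C=C/C(=O)/C=C/c2ccc(OCc3cn(CCCCOc4cc(=O)oc5ccccc45)nn3)c(OC)c2)cc1` share one core and differ only by 4-methoxyphenyl in place of 2-methoxyphenyl on a double-bonded chain carbon bound to a double-bonded chain carbon. In a functional assay on HCT-116 cells (Homo sapiens) for inhibition, read by sulforhodamine B assay, with a stated time of 48 h, tested at 50 uM (a higher number here means more inhibition of growth at the concentration tested, a lower number less inhibition of growth), compound 1 gives 43%, and compound 2 gives 40%; the step measured is a number 3 percentage points lower from compound 1 to compound 2 (within the scatter). Compound 3 `COc1ccccc1/C=C/C(=O)/C=C/c1ccc(OCc2cn(CCOc3cc(=O)oc4ccccc34)nn2)c(OC)c1` rests on another core, and the difference between the two cores is not broken down here. In this assay compound 3 gives 70%, the highest of the three, beyond the scatter from both compound 1 and compound 2. Compound 4 `COc1ccc(/C=C/C(=O)/C=C/c2ccc(OCc3cn(CCOc4cc(=O)oc5ccccc45)nn3)c(OC)c2)cc1` has not been measured; it carries the same change relative to compound 3, (4-methoxyphenyl in place of 2-methoxyphenyl on a double-bonded chain carbon bound to a double-bonded chain carbon), at the same place. Because the earlier step of a number 3 percentage points lower from compound 1 to compound 2 (within the scatter) stayed small, the step in this assay is expected to be similar, a number 4 percentage points lower from compound 3 to compound 4 (within the scatter). Compound 4 is therefore estimated at 66%, expected to fall between 52% and 78%.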

Compound 4, percent growth inhibition at one concentration: 71%
The estimate for compound 4 lay 5 percentage points below the measured number; low and high end bracket the measured number.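

On the core of compound 3, the exchange of 2-methoxyphenyl for 4-methoxyphenyl in this assay gives a number 1 percentage points higher from compound 3 to compound 4 (within the scatter), and the two cores do not separate on this change: the same change on two cores in this assay, a number 3 percentage points lower (within the scatter) from compound 1 to compound 2 and a number 1 percentage points higher (within the scatter) from compound 3 to compound 4, 4 percentage points apart, within the scatter of two such steps

Within these two pairs, the exchange therefore carries from one core to the other without a visible change in growth inhibition. Among the compounds shown here, this does not show that the step would stay as small on any further core, since it rests on only two pairs, each read at a single concentration in one cell line.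

The compounds shown leave open whether the site tolerates anything other than a methoxyphenyl group. A phenyl ring bearing an amine or a carboxylic acid at that place would test this, as would a chain longer than that of compound 1.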